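Imidazole for pyrazole on the piperazine-linked arm

The source may hold more compounds than are shown below. What is called first, only, known or untested is meant among the compounds shown, and "the series" means these compounds.

Measured compounds:
compound 1 `CCc1nc(C)c(CN2CCN(c3cccc4[nH]c(-c5ccc(C(C)(C)C)cc5)nc34)CC2)o1`, an assay on isolated protein for displacement of a labelled ligand from Gonadotropin-releasing hormone receptor (Rattus norvegicus) (a lower number here means a stronger inhibitor, a higher number a weaker inhibitor), 320 nM
compound 2 `CCc1cc(CN2CCN(c3cccc4[nH]c(-c5ccc(C(C)(C)C)cc5)nc34)CC2)nn1C`, this assay 350 nM
compound 3 `CCCCc1nc(CN2CCN(c3cccc4[nH]c(-c5ccc(C(C)(C)C)cc5)nc34)CC2)cn1C`, this assay 58 nM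

Compound 2 gives the highest number of the three in this assay, though compound 1 sits within the scatter of it, as the step of a 1.1-fold higher number from compound 1 to compound 2 (0.04 log units; within the scatter) shows; only compound 3 stands clearly apart from compound 2.

Compound 4 `CCn1cc(CN2CCN(c3cccc4[nH]c(-c5ccc(C(C)(C)C)cc5)nc34)CC2)nc1C` has not been measured. It differs from compound 2 in one place: 1-ethyl-2-methyl-1H-imidazol-4-yl in place of 5-ethyl-1-methyl-1H-pyrazol-3-yl on a saturated chain carbon bound to an amine nitrogen in a ring.

Within the data shown here, two measured steps bear on this change. The step of a 6.0-fold lower number from compound 2 to compound 3 (0.78 log units; beyond the scatter) and the step of a 5.5-fold lower number from compound 1 to compound 3 (0.74 log units; beyond the scatter) both show that an imidazol-4-yl group in this position gives a lower number than the pyrazolyl or oxazolyl groups. Compound 3, however, carries a 2-butyl-1-methyl-1H-imidazol-4-yl, whereas compound 4 carries a 1-ethyl-2-methyl-1H-imidazol-4-yl, so the lower number of compound 3 cannot be attributed to the ring alone. A step toward a lower number is therefore expected for compound 4, but smaller than the step to compound 3: the expected step is a 2.3-fold lower number from compound 2 to compound 4 (0.37 log units; beyond the scatter).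

Compound 4 is estimated at 150 nM in this assay, with a range from 50 nM to 450 nM.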

Compound 4, half-maximal inhibitory concentration: 51 nM
Compound 4: the middle estimate sits 2.9-fold (0.47 log units) above what was measured; measured number inside the range.
By their numbers in this assay, from the lowest: compounds 4 and 3 (each within the scatter of the next); then compounds 1 and 2 (each within the scatter of the next).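

The imidazol-4-yl advantage in this assay no longer rests on compound 3 alone: the step of a 6.9-fold lower number from compound 2 to compound 4 (0.84 log units; beyond the scatter) replaces one group with another of the same heavy atoms and the same counts, so here the two groups differ only in how those atoms are joined, and the step of a 6.3-fold lower number from compound 1 to compound 4 (0.80 log units; beyond the scatter) points the same way against the oxazole. The step of a 1.1-fold lower number from compound 3 to compound 4 (0.06 log units; within the scatter) lies within the scatter, so a 2-butyl chain is not needed for this level of binding, and 2-butyl-1-methyl-1H-imidazol-4-yl and 1-ethyl-2-methyl-1H-imidazol-4-yl cannot be told apart on this position. Nothing shown explains why the imidazoles give lower numbers than the pyrazole or the oxazole.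

Going by these compounds, compounds 3 and 4 differ in both chains on the imidazole at once, so the contribution of each chain cannot be separated, and how a smaller 1,2-dimethyl-1H-imidazol-4-yl or a longer 1-butyl-2-methyl-1H-imidazol-4-yl would behave stays open. Also open, on these data alone, is whether the imidazole result would hold for a ring with a third nitrogen, such as a 1,2,4-triazole, on the same saturated chain carbon.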